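This account rests on a few compounds, and the source may have more. Where it says the series, first, only, none or still open, it means among the compounds named here.

Measured so far:
- compound 1 `CCn1c(/C=C2/C(=O)Nc3ccccc32)nc2ccccc21`: > 50000 nM, a limit of the assay and not a number
- compound 2 `CC(C)n1c(/C=C2/C(=O)Nc3ccccc32)nc2ccccc21`: 40400 nM

In a functional assay on 4T1 cells (Homo sapiens) for cytotoxicity, read by MTT assay, with a stated time of 48 h (a higher number here means a weaker inhibitor, a lower number a stronger inhibitor), compound 1 gives > 50000 nM, which is a limit and not a number. Compound 3 `CCn1c(/C=C2/C(=O)Nc3ccc(Br)cc32)nc2ccccc21` keeps the core of compound 1 and carries bromo in place of hydrogen on an aromatic carbon. Going by the values given here, the only measured step is an at least 1.2-fold lower number from compound 1 to compound 2 (0.09 log units; that floor lies within the scatter), and it puts methyl in place of hydrogen on a saturated chain carbon, a different kind of change in a different place. Among the compounds with values here, it therefore gives little guidance on the size of this one, and no measured step covers a change on an aromatic carbon. Because of the limit of > 50000 nM in this assay, at which 1 of the 2 values shown sits, for compound 1, any number reported for compound 3 would most likely fall on the lower side, though a second limit remains possible. The step expected is modest: an at least 1.6-fold lower number from compound 1 to compound 3 (0.22 log units; that floor lies within the scatter). For compound 3 the estimated value is 30000 nM, with an expected range of 10000 nM to 50000 nM.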

Compound 3, half-maximal inhibitory concentration: 40700 nM
The estimate for compound 3 lay 1.4-fold (0.13 log units) below the measured number, within the range that was stated.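

In this assay, putting bromo in place of hydrogen on this aromatic carbon, meta to a fused ring and para to a fused ring, gives an at least 1.2-fold lower number from compound 1 to compound 3 (0.08 log units; that floor lies within the scatter). Going by these compounds alone, this is the first look at a change on the aromatic ring rather than on the saturated chain, and compound 3 gives a measured number on this ring while the parent does not. For compound 1, > 50000 nM is a limit and not a number, so the true size of this step stays unknown, and the floor alone cannot separate it from ordinary scatter: the limit of > 50000 nM in this assay, at which 1 of the 3 values shown sits.

On these data alone, whether chloro, methoxy or an amine on the same aromatic carbon would give a similar number remains open. So does whether bromo would have a comparable effect on the core of compound 2.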